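The source may report more compounds than this note shows. Statements on the series, on what has been measured and on what is new or still open speak of the compounds shown alone.

Three compounds built on a shared core carrying a coumarin-like fragment linked through a chain to a furoxan-type ring have been tested in an ADME assay on L02 cells (Homo sapiens) for cytotoxicity, read by MTT assay, with a stated time of 48 h; on this read-out higher numbers stand for weaker inhibition and lower numbers for stronger inhibition. Compound 1 `COc1cc2ccc(=O)oc2cc1OCCOc1no[n+]([O-])c1S(=O)(=O)c1ccccc1` gives 10900 nM. Compound 2 `COc1cc2ccc(=O)oc2cc1OCCCOc1no[n+]([O-])c1S(=O)(=O)c1ccccc1`, whose chain is one unit longer, gives 7820 nM. Compound 3 `COc1cc2ccc(=O)oc2cc1OCCCCCCOc1c[n+]([O-])on1`, with a longer chain and no sulfonyl group on its terminal ring, gives 12400 nM. Compound 2 thus gives the smallest of the three numbers, but its gap to compound 1 and its gap to compound 3 both lie within the usual scatter of this assay, so the three compounds cannot be told apart on cytotoxicity by these measurements alone.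

Compound 4 `COc1cc2cc(N)c(=O)oc2cc1OCCCOc1no[n+]([O-])c1S(=O)(=O)c1ccccc1` has not yet been measured. It differs from compound 2 in one place: amino in place of hydrogen on an aromatic carbon. For the measured compounds named here, no pair of measured compounds shows the effect of this change, so there is nothing in the data to indicate a direction. The expectation for compound 4 is therefore a number close to that of compound 2, with a step of a 1.0-fold lower number from compound 2 to compound 4 (0.02 log units; within the scatter) that is expected to fall within the scatter. On that basis compound 4 is estimated at 7500 nM, within a range from 3000 nM to 19000 nM.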

Compound 4, half-maximal inhibitory concentration: 9160 nM
Compound 4: middle estimate off by 1.2-fold (0.09 log units), on the low side; the range from low to high includes it.
By their numbers in this assay, from the lowest: compounds 2, 4, 1 and 3 (each within the scatter of the next).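

For the compounds shown here, until now, no two measured compounds differed in one place only, so nothing could be said about any single change. In this assay, going by these compounds alone, placing amino in place of hydrogen on an aromatic carbon, two atoms from the ring oxygen, gives a 1.2-fold higher number from compound 2 to compound 4 (0.07 log units; within the scatter) and so offers the first reading for this position. This shows that adding this one group at this carbon produces no difference that can be separated from ordinary repeat variation in this test of toxicity to L02 cells, though no information on why this is so is available here.

A single group at a single position cannot show how this carbon responds more generally, and larger or differently built groups such as an acetamide, a dimethylamino group or a carboxylic acid could give a different picture there. As far as these compounds go, it also remains open whether the amino group would behave the same way on the shorter chain of compound 1, or on compound 3, whose longer chain ends in a ring without the sulfonyl group.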